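Trimming the side group: from cyclopropyl to methyl

The source may hold more compounds than are shown below. What is called first, only, known or untested is meant among the compounds shown, and "the series" means these compounds.

In a functional assay on SW1573 cells (Homo sapiens) for antiproliferative activity, read by sulforhodamine B assay, with a stated time of 48 h (a higher number here means a weaker inhibitor of growth, a lower number a stronger inhibitor of growth), compound 1 (`CCCCC(C#CC(=O)OC)O/C=C/C(=O)OC`), which carries a butyl group, gives 240 nM as its reading. Compound 2 (`COC(=O)C#CC(O/C=C/C(=O)OC)C1CC1`), with cyclopropyl in that place, gives 1800 nM and holds the higher of the two numbers, which makes it the weaker inhibitor of growth so far. Compound 3 (`COC(=O)C#CC(C)O/C=C/C(=O)OC`) has not yet been measured. It differs from compound 2 by a single change (methyl in place of cyclopropyl on a saturated chain carbon bound to an oxygen on an unsaturated carbon and a triple-bonded carbon), methyl in place of cyclopropyl on a saturated chain carbon bound to an oxygen on an unsaturated carbon and a triple-bonded carbon. Among the measured compounds shown here, the only measured step that bears on this change is the one from butyl to cyclopropyl (a 7.5-fold higher number from compound 1 to compound 2 (0.88 log units; beyond the scatter)), which lies beyond the usual scatter. Methyl is smaller again, so with that step as the sole guide, a further rise in the number is expected in this assay, though one step that involves no methyl is thin support. The expected step is of moderate size (a 2.2-fold higher number from compound 2 to compound 3 (0.35 log units; beyond the scatter)). In this assay the estimate for compound 3 is 4000 nM (range 1300 nM to 12000 nM).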

Compound 3, concentration for 50% growth inhibition: 1700 nM
Compound 3: middle estimate off by 2.4-fold (0.37 log units), on the high side, and the stated range covers the measured number.
By their numbers in this assay, from the lowest: compound 1; then compounds 3 and 2 (each within the scatter of the next).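

In this assay, the swap of methyl for cyclopropyl at this position reads as a 1.1-fold lower number from compound 2 to compound 3 (0.02 log units; within the scatter), so the two groups cannot be told apart here, even though one carries a three-membered ring and the other has no ring at all. Butyl now stands apart from both groups, with a 7.1-fold higher number from compound 1 to compound 3 (0.85 log units; beyond the scatter) alongside the earlier 7.5-fold higher number from compound 1 to compound 2 (0.88 log units; beyond the scatter), so these three compounds show no steady trend: compound 2 and compound 3 sit level, and only compound 1 has a clearly lower number. Nothing measured here explains why butyl differs from the other two groups.

These three compounds leave open where between methyl and butyl the reading begins to change, which an ethyl or a propyl chain at the same carbon would help to settle. They also leave open whether a longer chain, such as hexyl, or a branched one, such as isobutyl, would give a lower number still or lose what butyl gains over methyl.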